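The source may hold more compounds than are shown below. What is called first, only, known or untested is meant among the compounds shown, and "the series" means these compounds.

Working notes on the series. Within the data shown here, in a functional assay on a cell-free system (Platelet, plasma, Homo sapiens) for inhibition (on this read-out lower numbers stand for stronger inhibition and higher numbers for weaker inhibition), compound 2 (`O=C(O)CCN1Cc2ccc(NC(=O)c3ccc4c(c3)CNCC4)cc2C1=O`) gives 1100 nM and holds the lower of the two numbers so far. Among the measured compounds shown here, the only other measured member, compound 1 (`O=C(O)CCN1Cc2ccc(NC(=O)c3ccc(C4CCNCC4)cc3)cc2C1=O`), gives 9600 nM in the same test, a gap beyond the scatter.

Next is compound 3 (`O=C(O)CN1Cc2ccc(NC(=O)c3ccc4c(c3)CNCC4)cc2C1=O`), not yet measured. It differs from compound 2 by carboxy in place of carboxymethyl on a saturated chain carbon bound to an amide-type nitrogen in a ring in one place: carboxy in place of carboxymethyl on a saturated chain carbon bound to an amide-type nitrogen in a ring. Cut one bond further out, this reads 2-carboxyethyl to carboxymethyl.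

For the measured compounds named here, no measured pair varies this chain, so the data give no direct size for such a step. Going by the values given here, the numbers of compound 1 at 9600 nM and compound 2 at 1100 nM show only that this pair is separated by more than the scatter. A real step toward weaker inhibition is expected, though with low confidence. The estimated change is a 3.6-fold higher number from compound 2 to compound 3 (0.56 log units; beyond the scatter) in this assay on this expectation. For compound 3 the expected value is 4000 nM within an estimated range of 1200 nM to 15000 nM for now.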

Compound 3, half-maximal inhibitory concentration: 120000 nM
Beside the measured number, compound 3's estimate is 30-fold (1.48 log units) below it; the whole stated range lies below it.
By their numbers in this assay, from the lowest: compound 2; then compound 1; then compound 3.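

In this assay the change from 2-carboxyethyl to carboxymethyl, on a saturated chain carbon bound to an amide-type nitrogen in a ring, gives a 110-fold higher number from compound 2 to compound 3 (2.04 log units; beyond the scatter), the first direct size for a change at this place. The place is therefore highly sensitive to this chain, even though the group that leaves and the group that enters differ only as 4 heavy atoms against 3, with the same counts of hydrogen-bond donors and acceptors and no net charge on either. Nothing at hand gives a reason for a step of this size.

As far as these compounds go, with only 2-carboxyethyl and carboxymethyl at this place, it remains open whether a longer chain such as 3-carboxypropyl would continue the trend toward lower numbers or reverse it, so no best chain length can be named yet. From the compounds shown here alone, it is equally open whether the carboxylic acid itself is needed on the chain, which a primary carboxamide or a tetrazole at the end of the 2-carboxyethyl chain length would test.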